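Methyl in Place of Hydrogen: Compound 1 to Compound 4

The source may hold more compounds than are shown below. What is called first, only, known or untested is meant among the compounds shown, and "the series" means these compounds.

Compound 1 `Cc1ccc(-c2nn(-c3ccccc3)cc2CNc2ccccc2)cc1`: in an ADME assay on MT4 cells (Homo sapiens) for cytotoxicity, read by MTT assay, with a stated time of 96 h (a lower number here means that less compound is tolerated, a higher number that more compound is tolerated), compound 1 reaches only the assay limit, > 100000 nM.
Compound 2 `Clc1ccc(NCc2cn(-c3ccccc3)nc2-c2ccc(Br)cc2)cc1`: compound 2 also reaches only a limit, > 100000 nM; > 100000 nM (2 entries).
Compound 3 `Brc1ccc(NCc2cn(-c3ccccc3)nc2-c2ccc(Br)cc2)cc1`: compound 3 likewise reaches only a limit, > 100000 nM.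

For the measured compounds named here, compound 1 thus stands at the limit of > 100000 nM in this assay, at which 2 of the 3 values shown sit, so it is not separated from the others by any measured step, and no step between measured compounds is recorded. Compound 4 `Cc1ccc(NCc2cn(-c3ccccc3)nc2-c2ccc(C)cc2)cc1` is the unmeasured partner of compound 1; the change is methyl in place of hydrogen on an aromatic carbon. With every shown value sitting at a limit, no step beyond the scatter is expected for compound 4: a number no higher from compound 1 to compound 4 (the limit leaves the size open). For compound 4 the expected value in this assay is 100000 nM, with the estimate ranging from 50000 nM to 200000 nM.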

Compound 4, half-maximal cytotoxic concentration: > 100000 nM
Compound 4 was reported as a limit; the forecaster's own chance of this, stated with the estimate: 85%; the middle value lies on the limit itself.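

Compound 1 and compound 4 both stand only at the assay limit, so no step can be read between them. The compounds shown leave open where the half-maximal cytotoxic concentration of each actually lies, and so whether methyl in place of hydrogen shifts it.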